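Propyl in Place of Hydrogen on the Core of Compound 3

This account rests on a few compounds, and the source may have more. Where it says the series, first, only, none or still open, it means among the compounds named here.

Compound 3 `Nc1ncnc2c1nc(O)n2Cc1ccccc1` stands highest of the three compounds measured in a functional assay (spleen, spleen) for activation, with Mus musculus as the target; on this read-out higher numbers stand for an effect only at larger amounts of compound and lower numbers for an effect already at smaller amounts: compound 3 gives 10 uM. Compound 1 `Nc1nc(O)nc2c1nc(O)n2Cc1ccccc1` gives 0.1 uM, and compound 2 `CCCCCOc1nc(N)c2nc(O)n(Cc3ccccc3)c2n1` gives 0.01 uM. Compound 4 `CCCc1nc(N)c2nc(O)n(Cc3ccccc3)c2n1` differs from compound 3 in one place: propyl in place of hydrogen on an aromatic carbon. Going by the values given here, two measured steps bear on this position. The change a 100-fold higher number from compound 1 to compound 3 (2.00 log units; beyond the scatter) and the change a 1000-fold higher number from compound 2 to compound 3 (3.00 log units; beyond the scatter) both show that a bare hydrogen on this aromatic carbon goes with a much higher number than a group there. Propyl is neither hydroxy nor pentyloxy, but it again puts a group on that carbon, so a large fall is expected, a 100-fold lower number from compound 3 to compound 4 (2.00 log units; beyond the scatter). Compound 4 is therefore estimated at 0.1 uM, with a range from 0.01 uM to 1 uM.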

Compound 4, minimum effective concentration: 1 uM
For compound 4 the middle estimate is 10-fold (1.00 log units) below the measured one; measured number inside the range.
By their numbers in this assay, from the lowest: compound 2; then compound 1; then compound 4; then compound 3.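

In this assay a group joined through carbon is enough for a step beyond the scatter on this aromatic carbon (a 10-fold lower number from compound 3 to compound 4 (1.00 log units; beyond the scatter)), so an oxygen at this point is not required for a lower number. Propyl still does not match either oxygen-linked group (a 10-fold higher number from compound 1 to compound 4 (1.00 log units; beyond the scatter); a 100-fold higher number from compound 2 to compound 4 (2.00 log units; beyond the scatter)), so the identity of the group matters as well as its presence. From the compounds shown here alone, whether an amine or a pentyl chain joined directly through carbon would come closer to pentyloxy stays open. Nothing given here accounts for the order of these groups.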